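The source may report more compounds than this note shows. Statements on the series, on what has been measured and on what is new or still open speak of the compounds shown alone.

Working notes on the series. All four compounds share one core, joined through an ether and a triazole to a substituted benzyl group, and differ only in that benzyl. Compound 1 `Cc1cccc(Cn2cc(COc3ccc4c(=O)ccoc4c3)nn2)c1` carries a 3-methylphenyl and in a functional assay on SW480 cells (Homo sapiens) for cytotoxicity, read by MTT assay, with a stated time of 48 h (a higher number here means a weaker inhibitor, a lower number a stronger inhibitor), compound 1 gives 11700 nM. Compound 3 `CC(C)(C)c1ccc(Cn2cc(COc3ccc4c(=O)ccoc4c3)nn2)cc1` carries a 4-tert-butylphenyl and in this assay compound 3 gives 28800 nM. Compound 2 `O=c1ccoc2cc(OCc3cn(Cc4ccccc4Br)nn3)ccc12` carries a 2-bromophenyl and in this assay compound 2 reaches only a limit of the assay, > 100000 nM. Compound 2 therefore stands at the limit of > 100000 nM in this assay, at which 1 of the 3 values shown sits, and no number is available for it.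

Among the measured compounds shown here, the one measured step that touches compound 2 is an at least 8.5-fold higher number from compound 1 to compound 2 (0.93 log units; beyond the scatter), a change of the whole aryl group. The move to compound 4 `O=c1ccoc2cc(OCc3cn(Cc4ccccc4Cl)nn3)ccc12` is smaller: chloro in place of bromo on an aromatic carbon. For the measured compounds named here, no measured step exchanges one halogen for another, so the 2-bromophenyl-to-2-chlorophenyl change has no direct precedent here; the measured step only fixes where compound 2 starts, at the limit.

Going by the values given here, with no step of this kind on record, compound 4 is expected to stay close to compound 2, with a number no higher from compound 2 to compound 4 (the limit leaves the size open) expected to remain within the scatter. Compound 4 is thus estimated at 100000 nM in this assay, with a range from 30000 nM to 300000 nM, and a fair chance that it is again reported only as a limit.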

Compound 4, half-maximal inhibitory concentration: 23500 nM
For compound 4 the middle estimate is 4.3-fold (0.63 log units) above the measured one; measured number below the stated range.
By their numbers in this assay, from the lowest: compounds 1, 4 and 3 (each within the scatter of the next, the first and the last beyond it). At a limit, above all of these: compound 2.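

Among the compounds shown here, the chloro in place of bromo change on an aromatic carbon is the first halogen exchange, and it does not leave the number in place in this assay: the step is an at least 4.2-fold lower number from compound 2 to compound 4 (0.62 log units; beyond the scatter). The 2-chlorophenyl and the 3-methylphenyl are not told apart, with a 2.0-fold higher number from compound 1 to compound 4 (0.30 log units; within the scatter), so among the compounds shown, a halogen on this aromatic carbon does not by itself carry the series out to the limit, and that outcome stays with the bromo. Compound 2 remains a limit and not a number, so the full size of the step cannot be read: the limit of > 100000 nM in this assay, at which 1 of the 4 values shown sits.

The compounds shown leave open whether the bromo is the exception or the start of a trend across the halogens, which a 2-fluorophenyl or 2-iodophenyl would help to settle. They also leave open how far the halogen matters at all on this aromatic carbon, since a 2-methylphenyl, a 2-methoxyphenyl or a 2-aminophenyl would set non-halogen groups at the same place and separate the effect of the group from that of its position.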